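A few compounds are considered here, and "the series" means these few. Any claim that something is new, unique, unknown or untested is made for them only; others in the source may bear on it.

For the measured compounds named here, in a functional assay on PC-9 cells (Homo sapiens) for antiproliferative activity, read by MTT assay, with a stated time of 72 h (on this read-out lower numbers stand for stronger inhibition and higher numbers for weaker inhibition), two compounds have numbers so far. Compound 1, `COc1ccc(Nc2cc(NC(=O)c3ccccc3)ncn2)cc1`, gives 660 nM, and compound 2, `O=C(Nc1cc(Nc2ccc(Cl)cc2)ncn1)c1ccc(F)cc1`, gives 820 nM. These values lie within the usual scatter of repeated measurements, so compound 1 stands level with compound 2 and neither can be ranked over the other. Going by the values given here, the two structures differ in more than one place, so no measured pair isolates a single change.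

Compound 3, `CCOc1ccc(Nc2cc(NC(=O)c3ccccc3)ncn2)cc1`, differs from compound 1 in one place only: methyl in place of hydrogen on a saturated chain carbon bound to an oxygen on an aromatic ring. This is methyl in place of hydrogen on a saturated chain carbon bound to an oxygen on an aromatic ring, or methoxy to ethoxy. No measurement shows the effect of this change directly. In this assay, no step beyond the scatter is expected, in either direction. Despite its different groups, compound 2 at 820 nM stays within the scatter of compound 1, and this edit is smaller. The estimated step of a 1.1-fold lower number from compound 1 to compound 3 (0.04 log units; within the scatter) is therefore small. For compound 3 the estimated value is 600 nM, with an expected range from 250 nM to 1400 nM.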

Compound 3, half-maximal inhibitory concentration: 2090 nM
The estimate for compound 3 lay 3.5-fold (0.54 log units) below the measured number, and the stated range ends below it.
By their numbers in this assay, from the lowest: compounds 1 and 2 (each within the scatter of the next); then compound 3.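

In this assay going from methoxy to ethoxy gives a 3.2-fold higher number from compound 1 to compound 3 (0.50 log units; beyond the scatter), so the group on this saturated chain carbon bound to an oxygen on an aromatic ring does matter to the read-out. The earlier compounds shown here could not show this: compounds 1 and 2 differ in more than one place, whereas here a single methyl in place of hydrogen, 1 heavy atom, moves the number beyond the usual scatter and toward weaker inhibition. No measurement at hand accounts for this loss, so the data give its size and not its origin.

With only methoxy and ethoxy at this place, a single step cannot tell whether the number keeps climbing as the chain grows, as a propyl or longer chain would reveal, or whether the change is particular to ethyl. From the compounds shown here alone, it also remains open how a chain ending in an amine or a hydroxyl group would read here, and whether the same edit would have a step of similar size on another member of the series.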